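A few compounds are considered here, and "the series" means these few. Any claim that something is new, unique, unknown or untested is made for them only; others in the source may bear on it.

Three compounds have so far been measured in an ADME assay on L6 cells (Rattus norvegicus) for cytotoxicity, read by resazurin assay, with a stated time of 70 h; a lower number here means a stronger inhibitor, a higher number a weaker inhibitor:

compound 1, `N=C(N)c1ccc2oc(-c3cccc(OCCCCCOc4ccccc4)c3)cc2c1`, giving 3000 nM
compound 2, `CC(C)NC(=N)c1ccc2oc(-c3cccc(OCCCCCOc4ccccc4)c3)cc2c1`, giving 10100 nM
compound 3, `N=C(N)c1ccc2cc(-c3cccc(OCCCCOc4ccccc4)c3)oc2c1`, giving 7600 nM

Compound 1 and compound 2 share a core and differ in one place only: isopropyl in place of hydrogen on an amine nitrogen. In this assay this change produced a 3.4-fold higher number from compound 1 to compound 2 (0.53 log units; beyond the scatter), a step that lies beyond the usual scatter of repeated measurements.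

Compound 3 is built on a different core from compound 1; the difference between the two cores is not broken down here. Compound 4, `CC(C)NC(=N)c1ccc2cc(-c3cccc(OCCCCOc4ccccc4)c3)oc2c1`, has not yet been measured. It differs from compound 3 in one place: isopropyl in place of hydrogen on an amine nitrogen. The place where the group enters is described in the same words for both pairs, so this is the same change, now made on the core of compound 3.

For the measured compounds named here, with only one earlier example of this change to go on, the expectation rests on that single step. The step from compound 3 to compound 4 in this assay is expected to be about a 3.2-fold higher number from compound 3 to compound 4 (0.50 log units; beyond the scatter), since the same change earlier gave a 3.4-fold higher number from compound 1 to compound 2 (0.53 log units; beyond the scatter). Compound 3 already sits at a higher number than compound 1, so compound 4 is expected to sit higher still. Compound 4 is estimated at 24000 nM in this assay, with a likely range from 10000 nM to 60000 nM.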

Compound 4, half-maximal inhibitory concentration: 46500 nM
Beside the measured number, compound 4's estimate is 1.9-fold (0.29 log units) below it; the range from low to high includes it.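

In this assay, placing isopropyl where a hydrogen sat on the amine nitrogen gave a 6.1-fold higher number from compound 3 to compound 4 (0.79 log units; beyond the scatter), so a higher number, meaning a weaker inhibitor, appeared on the core of compound 3 just as it had on the core of compound 1. Set side by side, the two steps differ by no more than repeated measurements of this kind would be expected to, so they can be treated as alike in size: the same change on two cores in this assay, a 3.4-fold higher number (0.53 log units; beyond the scatter) from compound 1 to compound 2 and a 6.1-fold higher number (0.79 log units; beyond the scatter) from compound 3 to compound 4, 1.8-fold (0.26 log units) apart, within the scatter of two such steps. This shows that, across these two pairs, the change carried over from one core to the other in direction and, as far as the scatter allows one to tell, in size, but it does not show that the step is truly larger on the core of compound 3, nor that the same step would appear on any further core.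

The compounds shown leave open whether a smaller group on that nitrogen, such as methyl or ethyl, would raise the number as much as isopropyl does. They also leave open whether a ring on that nitrogen, such as cyclopentyl, would follow the same trend on both cores.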